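Shortening the Side Chain of Compound 2

The compounds below may be only part of what the source reports. "The series", "measured", "known", "first", "only" and "open" are said of these compounds alone.

Measured so far in a functional assay on HCT-116 cells (Homo sapiens) for cytotoxicity, read by MTT assay, with a stated time of 72 h; a lower number here means a stronger inhibitor, a higher number a weaker inhibitor:
- compound 1 (`O=C1c2c[n+]([O-])c3ccccc3c2C(=O)c2c1c1ccccc1n2Cc1cn([C@H]2O[C@H](CO)[C@@H](O)[C@H]2O)nn1`) gives 710 nM
- compound 2 (`CN1CCN(CCCCn2c3c(c4ccccc42)C(=O)c2c[n+]([O-])c4ccccc4c2C3=O)CC1`) gives 10 nM
- compound 3 (`O=C1c2c[n+]([O-])c3ccccc3c2C(=O)c2c1c1ccccc1n2Cc1cn([C@H]2C[C@H](O)[C@@H](CO)O2)nn1`) gives 120 nM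

Compound 2 has the lowest number of the three, and the gaps to compound 1 and compound 3 both lie beyond the scatter. Compound 4 (`O=C1c2c[n+]([O-])c3ccccc3c2C(=O)c2c1c1ccccc1n2CCN1CCCCC1`) carries piperidin-1-yl in place of 2-(4-methylpiperazin-1-yl)ethyl on a saturated chain carbon, two bonds along the chain from an aromatic nitrogen. Within the data shown here, the only measured step, a 5.9-fold lower number from compound 1 to compound 3 (0.77 log units; beyond the scatter), is modest and involves a different group, so it gives only a rough sense of size for this change. Among the measured compounds shown here, no measured step tests the change directly. Since compound 2 sits at the low end of the set, a modest move toward a higher number is expected in this assay. The expected move is a 3.5-fold higher number from compound 2 to compound 4 (0.54 log units; beyond the scatter) in size. For compound 4 the estimated value is 35 nM, with an expected range from 8 nM to 150 nM.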

Compound 4, half-maximal inhibitory concentration: 780 nM
Beside the measured number, compound 4's estimate is 22-fold (1.35 log units) below it, and the stated range ends below it.
By their numbers in this assay, from the lowest: compound 2; then compound 3; then compounds 1 and 4 (each within the scatter of the next).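

In this assay, putting piperidin-1-yl in place of 2-(4-methylpiperazin-1-yl)ethyl on a saturated chain carbon, two bonds along the chain from an aromatic nitrogen, gives a 78-fold higher number from compound 2 to compound 4 (1.89 log units; beyond the scatter). Among these compounds, the only earlier step was modest and lay in a different group, whereas this one shows that the number in this assay can depend heavily on the side chain of compound 2. No available evidence accounts for the size of this step.

The change shortens the chain and replaces the ring in one move, so the compounds shown leave open how much each contributes. A 4-(piperidin-1-yl)butyl group or a 2-(4-methylpiperazin-1-yl)ethyl group in the same place would separate the two.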